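This account rests on a few compounds, and the source may have more. Where it says the series, first, only, none or still open, it means among the compounds named here.

In a functional assay on the whole organism (strain albino) for inhibition, with Rattus norvegicus as the target, read by paw edema, with stated times of 1 h and 0.5 h, at a dose of 100 mg/kg by the oral route (a lower number here means less inhibition, a higher number more inhibition at the dose given (going by the name of the read-out)), compound 1 `N#Cc1c(-c2ccc(O)cc2)nc(SCC(=O)Nn2c(COc3ccc(Cl)cc3Cl)nc3ccccc3c2=O)[nH]c1=O` gives 61.5%, the highest of the two numbers seen. Within the data shown here, compound 2 `O=C(CSc1nc(-c2ccc(O)cc2)c(C(=O)O)c(=O)[nH]1)Nn1c(COc2ccc(Cl)cc2Cl)nc2ccccc2c1=O` gives 32.7% in this assay, and the step of a number 28.8 percentage points lower from compound 1 to compound 2 (beyond the scatter) is the only measured change. Compound 3 `N#Cc1c(-c2ccc(O)cc2)nc(SCC(=O)Nn2c(COc3ccc(Cl)cc3Cl)nc3ccccc3c2=O)n(Cc2ccccc2)c1=O` differs from compound 1 by benzyl in place of hydrogen on an aromatic nitrogen. Among the measured compounds shown here, no measured step touches that aromatic nitrogen, so the change from compound 1 to compound 3 has no precedent here, and nothing in the data points to a direction. Compound 3 is therefore expected to give roughly 50% in this assay, between 25% and 75%, an expected step of a number 11.5 percentage points lower from compound 1 to compound 3 (beyond the scatter).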

Compound 3, a percentage reported as inhibition, in the whole organism at one dose (the size of the read-out at that dose, not a potency): 51.9%
For compound 3 the middle estimate is 1.9 percentage points below the measured one; low and high end bracket the measured number.
By their numbers in this assay, from the lowest: compound 2; then compounds 3 and 1 (each within the scatter of the next).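

In this assay the benzyl on the aromatic nitrogen amounts to a number 9.6 percentage points lower from compound 1 to compound 3 (within the scatter) and so does not separate the two compounds. This shows that the aromatic nitrogen, untouched by the earlier step on the nitrile, can carry a group of seven carbons with the read-out staying within the scatter of compound 1. No measurement at hand offers an explanation for this result.

As far as these compounds go, whether a methyl or an aminoethyl chain on that nitrogen would behave like benzyl remains open. So does whether a substituted benzyl would stay within the scatter of compound 1.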